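Replacing the bromophenyl arm: expectation for compound 4

This account rests on a few compounds, and the source may have more. Where it says the series, first, only, none or still open, it means among the compounds named here.

Going by the values given here, compound 1 `COc1cccc(/C=C2\CCC/C(=C\c3ccccc3Br)C2=O)c1OC` gives 12100 nM in a functional assay on SW-620 cells (Homo sapiens) for cytotoxicity, read by MTT assay, with a stated time of 72 h (on this read-out higher numbers stand for weaker inhibition and lower numbers for stronger inhibition), the highest of the three numbers measured so far. Compound 2 `COc1cccc(/C=C2\CCC/C(=C\c3cccc(OC)c3OC)C2=O)c1` gives 7000 nM and compound 3 `COc1cccc(/C=C2\CCC/C(=C\c3cccc(O)c3)C2=O)c1OC` gives 6400 nM. The steps of a 1.7-fold lower number from compound 1 to compound 2 (0.24 log units; within the scatter) and a 1.9-fold lower number from compound 1 to compound 3 (0.28 log units; within the scatter) both lie within the scatter, as does a 1.1-fold lower number from compound 2 to compound 3 (0.04 log units; within the scatter). Compound 4 `COc1cccc(/C=C2\CCC/C(=C\c3cc(Cl)cc(Cl)c3)C2=O)c1OC` differs from compound 1 by 3,5-dichlorophenyl in place of 2-bromophenyl on a double-bonded chain carbon bound to a double-bonded ring carbon. The two measured steps that swap the same 2-bromophenyl for another aryl group bear directly on this change, and neither moved the number beyond the scatter. No step beyond the scatter is therefore expected for a 1.3-fold lower number from compound 1 to compound 4 (0.13 log units; within the scatter), since the nearest precedents a 1.7-fold lower number from compound 1 to compound 2 (0.24 log units; within the scatter) and a 1.9-fold lower number from compound 1 to compound 3 (0.28 log units; within the scatter) stayed within it. Compound 4 is estimated at 9000 nM, with a range from 3000 nM to 27000 nM.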

Compound 4, half-maximal inhibitory concentration: 5500 nM
Estimate against measurement, compound 4: 1.6-fold (0.21 log units) above, within the range that was stated.
By their numbers in this assay, from the lowest: compounds 4, 3, 2 and 1 (each within the scatter of the next, the first and the last beyond it).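

Going by these compounds alone, at this place, on a double-bonded chain carbon bound to a double-bonded ring carbon, the swap to 3,5-dichlorophenyl gives the first step beyond the scatter in this assay: a 2.2-fold lower number from compound 1 to compound 4 (0.34 log units; beyond the scatter). That step is modest and does not set the new aryl group apart from the other replacements, as a 1.2-fold lower number from compound 3 to compound 4 (0.07 log units; within the scatter) and a 1.3-fold lower number from compound 2 to compound 4 (0.10 log units; within the scatter) both stay within the scatter. Nothing available accounts for the step.

Still open, from the compounds shown here alone, is how an aryl group carrying an amine or a carboxylic acid reads at this place. Also open, going by these compounds, is whether a single chlorine on the phenyl ring gives a similar number.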